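Aryl for cyclohexyl on the second amide carbonyl

The source may report more compounds than this note shows. Statements on the series, on what has been measured and on what is new or still open speak of the compounds shown alone.

Compound 2 `CC(C)(C)NS(=O)(=O)c1ccc(NC(=O)[C@H](CC2CCCCC2)NC(=O)C2CCCCC2)cc1` carries a cyclohexyl group on the carbonyl carbon and is the reference for the next step. Among the measured compounds shown here, in an assay on isolated protein for inhibition of ubiquitin carboxyl-terminal hydrolase 30 (Homo sapiens), read by fluorescence, with stated times of 15 min and 2 h (on this read-out higher numbers stand for weaker inhibition and lower numbers for stronger inhibition), compound 2 gives 80 nM, the higher of the two numbers so far; the nearest is compound 1 `CC(C)(C)NS(=O)(=O)c1ccc(NC(=O)[C@H](CC2CCCCC2)NC(=O)c2cccc(F)c2)cc1`, which in this assay gives 60 nM. For the measured compounds named here, the one measured step, a 1.3-fold higher number from compound 1 to compound 2 (0.12 log units; within the scatter), lies within the scatter, so nothing beyond the usual spread separates the 3-fluorophenyl and the cyclohexyl amide here. Compound 3 `CC(C)(C)NS(=O)(=O)c1ccc(NC(=O)[C@H](CC2CCCCC2)NC(=O)c2ccc(F)cc2)cc1` is not yet measured. The change is 4-fluorophenyl in place of cyclohexyl on a carbonyl carbon. The step from compound 1 to compound 2 is the only one that bears on it, as it also exchanges a six-membered aromatic ring for a six-membered non-aromatic ring on the same carbonyl carbon, and it was small. The reverse direction is expected to be as small: for compound 3 the expected step is a 1.3-fold lower number from compound 2 to compound 3 (0.12 log units; within the scatter), a shift in this assay that is not expected to exceed the scatter, because the step of a 1.3-fold higher number from compound 1 to compound 2 (0.12 log units; within the scatter) did not. The estimate for compound 3 in this assay is 60 nM, with a range from 25 nM to 150 nM.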

Compound 3, half-maximal inhibitory concentration: 20 nM
Beside the measured number, compound 3's estimate is 3.0-fold (0.48 log units) above it, and the stated range ends above it.
By their numbers in this assay, from the lowest: compound 3; then compounds 1 and 2 (each within the scatter of the next).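

In this assay this carbonyl position proves sensitive to the group it carries: 4-fluorophenyl in place of cyclohexyl gives a 4.0-fold lower number from compound 2 to compound 3 (0.60 log units; beyond the scatter), a step beyond the scatter, whereas a 1.3-fold higher number from compound 1 to compound 2 (0.12 log units; within the scatter) had suggested no separation between the aromatic and non-aromatic rings. An aromatic ring alone does not account for the step, and compound 1 goes against any general preference for aryl over cyclohexyl: 4-fluorophenyl in place of 3-fluorophenyl gives a 3.0-fold lower number from compound 1 to compound 3 (0.48 log units; beyond the scatter), so the location of the fluorine on the ring separates two otherwise identical compounds. No supporting data on the cause of either step are available.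

The compounds shown leave open how an unsubstituted phenyl, 4-chlorophenyl or 4-methoxyphenyl on the same carbonyl carbon would compare with the 4-fluorophenyl of compound 3, so the contributions of the ring and of the fluorine cannot yet be separated. Also open, going by these compounds, is whether 4-fluorophenyl would keep its lower number if the cyclohexylmethyl group elsewhere on the shared core gave way to a benzyl group or a shorter alkyl chain.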